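The source may hold more compounds than are shown below. What is called first, only, known or untested is meant among the compounds shown, and "the series" means these compounds.

- compound 1 `CSCCSc1nc(NCc2ccc(-c3ccccn3)cc2)c2[nH]nc(C(C)C)c2n1` gives 975 nM
- compound 2 `CC(C)c1n[nH]c2c(NCc3ccc(-c4ccccn4)cc3)nc(SCCCN)nc12` gives 120 nM

In a functional assay on HT cells (Homo sapiens) for antiproliferative activity, read by fluorescence, with a stated time of 72 h (on this read-out higher numbers stand for weaker inhibition of growth and lower numbers for stronger inhibition of growth), compound 2 has the lower of the two numbers (120 nM). Compound 3 `COCSc1nc(NCc2ccc(-c3ccccn3)cc2)c2[nH]nc(C(C)C)c2n1` differs from compound 2 by one change: methoxy in place of 2-aminoethyl on a saturated chain carbon bound to a sulfur. Among the measured compounds shown here, one measured step bears on this: an 8.1-fold lower number from compound 1 to compound 2 (0.91 log units; beyond the scatter) (aminomethyl in place of methylsulfanyl). Compound 3 has no amine, and neither has compound 1 (975 nM), so a return to a similar number is expected. The expected step is a 6.7-fold higher number from compound 2 to compound 3 (0.82 log units; beyond the scatter) (a higher number, beyond the scatter). For compound 3 the estimated value is 800 nM (range 250 nM to 2500 nM).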

Compound 3, concentration for 50% growth inhibition: 340 nM
Estimate against measurement, compound 3: 2.4-fold (0.37 log units) above, and the stated range covers the measured number.
By their numbers in this assay, from the lowest: compound 2; then compound 3; then compound 1.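

In this assay, losing the amine does not by itself take the number back to that of compound 1: the change gives a 2.8-fold higher number from compound 2 to compound 3 (0.45 log units; beyond the scatter) and, against the other amine-free compound, a 2.9-fold lower number from compound 1 to compound 3 (0.46 log units; beyond the scatter) as well. Among the compounds shown here, compound 3 therefore sits between the other two, so the 3-aminopropyl chain on the sulfur is not the only change here that lowers the number. On these data alone, whether a carboxylic acid or a longer chain ending in an amine would improve on compound 2 remains open. Nothing measured here explains why these chains give different numbers.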